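The source may hold more compounds than are shown below. What is called first, only, known or untested is meant among the compounds shown, and "the series" means these compounds.

Compound 1 `COc1ccc(-c2ccnc(C(=O)Nc3ccc(Oc4ccnc5[nH]ccc45)cc3)c2)cc1`: 6970 nM in a functional assay on A549 cells (Homo sapiens) for cytotoxicity, read by MTT assay, with a stated time of 72 h; on this read-out lower numbers stand for stronger inhibition and higher numbers for weaker inhibition. Compound 2 `O=C(Nc1ccc(Oc2ccnc3[nH]ccc23)cc1)c1cc(-c2ccc(C(F)(F)F)cc2)ccn1`: 3950 nM.

Compound 1 has the highest of the two numbers in this assay, and its nearest neighbour is compound 2, reached by a 1.8-fold lower number from compound 1 to compound 2 (0.25 log units; within the scatter). Compound 3 `COc1ccc(-c2ccnc(C(=O)Nc3ccc(Oc4ccnc5[nH]ccc45)c(F)c3)c2)cc1` has not been measured; it differs from compound 1 by fluoro in place of hydrogen on an aromatic carbon. Going by the values given here, no measured step concerns this change, and the single step that is known, a 1.8-fold lower number from compound 1 to compound 2 (0.25 log units; within the scatter), alters a different group and stays within the scatter. Compound 3 is therefore expected to show no step beyond the scatter, a 1.2-fold lower number from compound 1 to compound 3 (0.07 log units; within the scatter). Compound 3 is estimated at 6000 nM, between 2500 nM and 15000 nM.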

Compound 3, half-maximal inhibitory concentration: 1040 nM
Estimate against measurement, compound 3: 5.8-fold (0.76 log units) above; the whole stated range lies above it.
By their numbers in this assay, from the lowest: compound 3; then compounds 2 and 1 (each within the scatter of the next).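

Fluoro in place of hydrogen on an aromatic carbon, ortho to a large group and meta to a large group, gives the only step shown that lies beyond the scatter in this assay (a 6.7-fold lower number from compound 1 to compound 3 (0.83 log units; beyond the scatter)). The trifluoromethyl for methoxy change (a 1.8-fold lower number from compound 1 to compound 2 (0.25 log units; within the scatter)) stays within it, so this one added fluorine atom moves the number further than that exchange does. No measured data shown here account for this step.

From the compounds shown here alone, whether chloro or methyl at the same place would give a similar step remains open. So does whether fluoro there would lower the number of compound 2 as well.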